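The source may report more compounds than this note shows. Statements on the series, on what has been measured and on what is new or still open speak of the compounds shown alone.

In a functional assay on MDA-MB-231 cells (Homo sapiens) for antiproliferative activity, read by MTT assay, with a stated time of 24 h (on this read-out lower numbers stand for stronger inhibition and higher numbers for weaker inhibition), compound 1 `O=C(O)CC(NC(=O)c1ccc(Cl)cc1Cl)c1ccccc1F` gives 89300 nM. Compound 2 `COc1ccccc1C(=O)NC(CC(=O)O)c1ccc(Cl)cc1Cl` gives > 100000 nM, which is a limit of the assay and not a number. Compound 3 `O=C(O)CC(NC(=O)c1ccc(Cl)cc1Cl)c1ccc(Cl)cc1Cl` differs from compound 2 by a single change: 2,4-dichlorophenyl in place of 2-methoxyphenyl on a carbonyl carbon. Compound 1, at 89300 nM, also carries 2,4-dichlorophenyl on a carbonyl carbon, so only a small gain in this assay is expected, close to the scatter. The expected change is an at least 1.4-fold lower number from compound 2 to compound 3 (0.15 log units; that floor lies within the scatter). Compound 3 is estimated at 70000 nM, with an expected range of 30000 nM to 130000 nM.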

Compound 3, half-maximal inhibitory concentration: 49200 nM
Compound 3: middle estimate off by 1.4-fold (0.15 log units), on the high side; the measured number falls inside the stated range.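

In this assay, 2,4-dichlorophenyl in place of 2-methoxyphenyl on a carbonyl carbon gives an at least 2.0-fold lower number from compound 2 to compound 3 (0.30 log units; that floor lies within the scatter). Going by these compounds, this step starts from a limit of the assay, so it gives only a floor, and its true size stays unknown: the limit of > 100000 nM in this assay, at which 1 of the 3 values shown sits. At the saturated chain carbon bound to an amide-type nitrogen and a saturated chain carbon, 2,4-dichlorophenyl in place of 2-fluorophenyl gives a 1.8-fold lower number from compound 1 to compound 3 (0.26 log units; within the scatter).

On these data alone, it remains open whether an aminophenyl group or a longer alkyl chain on that carbonyl carbon would shift the number beyond the scatter.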